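A few compounds are considered here, and "the series" means these few. Any claim that something is new, unique, unknown or untested is made for them only; others in the source may bear on it.

Measured so far in a functional assay on SF-539 cells (Homo sapiens) for inhibition, read by sulforhodamine B assay, with a stated time of 48 h; on this read-out higher numbers stand for lower toxicity in this test and lower numbers for higher toxicity in this test:
- compound 1 `Nc1cc(N)c2nc(-c3ccccc3)c(Oc3ccc(Cl)c(Cl)c3)nc2c1`: 64600 nM
- compound 3 `COc1cc(CNc2nc3cc(N)cc(N)c3nc2-c2ccccc2)cc(OC)c1OC`: 26900 nM
- compound 2 `CCOC(=O)[C@H](CCC(=O)O)NC(=O)c1ccc(CNc2nc3cc(N)cc(N)c3nc2-c2ccccc2)cc1`: < 100000 nM, a limit of the assay, not a number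

Compound 1 stands at the higher of the two numbers in this assay; compound 3 gives 26900 nM, a lower number, and that gap is beyond the scatter. Compound 2 is recorded only as a limit. Compound 4 `Nc1cc(N)c2nc(-c3ccccc3)c(Sc3ccc(Cl)c(Cl)c3)nc2c1` differs from compound 1 by (3,4-dichlorophenyl)sulfanyl in place of 3,4-dichlorophenoxy on an aromatic carbon. Among the measured compounds shown here, no measured pair shows this change, so the step from compound 1 to compound 4 is expected to stay within the scatter, a 1.2-fold lower number from compound 1 to compound 4 (0.07 log units; within the scatter), with no clear direction. Compound 4 is therefore estimated at 55000 nM, within 20000 nM to 130000 nM.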

Compound 4, concentration lethal to 50% of the cells: < 100000 nM
Compound 4 ended at the assay's limit; the forecaster's own chance of this, stated with the estimate: 25%; the middle value lies beyond the limit too.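

Among the compounds shown here, compound 4 is recorded only as a limit, so no step from compound 1 to compound 4 can be read: the limit of < 100000 nM in this assay, at which 2 of the 4 values shown sit. From the compounds shown here alone, whether (3,4-dichlorophenyl)sulfanyl in place of 3,4-dichlorophenoxy shifts the number at all remains open.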